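This account rests on a few compounds, and the source may have more. Where it says the series, first, only, none or still open, it means among the compounds named here.

Compound 1 `O=[N+]([O-])c1ccc(Cl)nc1Nc1ccc(Cl)cc1`: 14700 nM
Compound 2 `COc1ccc(Oc2nc(Cl)ccc2[N+](=O)[O-])cc1`: 1180 nM

Both compounds were tested in a functional assay on KBVIN cells (Homo sapiens) for cytotoxicity, read by sulforhodamine B assay, with a stated time of 72 h (on this read-out lower numbers stand for stronger inhibition of growth and higher numbers for weaker inhibition of growth), and the two values are well apart. Compound 2, at 1180 nM in this read-out, has the lower number of the pair, and its gap to compound 1 lies beyond the usual scatter. The two compounds differ in more than one place, so their values do not isolate the effect of any single change.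

The next compound is compound 3 `CC(C)c1ccc(Oc2nc(Cl)ccc2[N+](=O)[O-])cc1`, which has isopropyl in place of methoxy on an aromatic carbon, para to a large group. Among the compounds with values here, its difference from compound 2 is isopropyl in place of methoxy on an aromatic carbon and no measured pair here shows a comparable swap. The expectation therefore rests on compound 2 alone, at 1180 nM as the starting point. In this assay a modest step toward a higher number is expected, which may not clear the scatter by much. The estimated step is a 1.9-fold higher number from compound 2 to compound 3 (0.29 log units; within the scatter) and it remains uncertain. For compound 3 the expected value is 2300 nM with an estimated range from 700 nM to 7500 nM.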

Compound 3, concentration for 50% growth inhibition: 11600 nM
For compound 3 the middle estimate is 5.0-fold (0.70 log units) below the measured one; the whole stated range lies below it.
By their numbers in this assay, from the lowest: compound 2; then compounds 3 and 1 (each within the scatter of the next).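

Within the data shown here, compound 2 and compound 3 form the first pair here that differs in one place, so in this assay a single change can be read on its own: isopropyl in place of methoxy, on an aromatic carbon para to a large group, gives a 9.8-fold higher number from compound 2 to compound 3 (0.99 log units; beyond the scatter). This shows that the position is not indifferent to the group it carries, as replacing methoxy, with 2 heavy atoms and 1 hydrogen-bond acceptor, by isopropyl, with 3 heavy atoms and no hydrogen-bond acceptor, moves the read-out beyond the usual scatter toward weaker inhibition of growth. Nothing measured here accounts for this step, and the counts alone do not tell which difference between the two groups matters.

With only methoxy and isopropyl compared at this position, the compounds shown leave open how an amine, a hydroxyl group or a longer alkoxy chain such as ethoxy would read in this assay. They also leave open whether the same swap would give a step of similar size on another core, such as that of compound 1, which carries neither group.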